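A Bromo Exchange on a Weak Growth Inhibitor

The source may hold more compounds than are shown below. What is called first, only, known or untested is meant among the compounds shown, and "the series" means these compounds.

In a functional assay on K562 cells (Homo sapiens) for inhibition, read by sulforhodamine B assay, with a stated time of 48 h (a lower number here means a stronger inhibitor of growth, a higher number a weaker inhibitor of growth), compound 1 (`CC(C)(C)NCc1c(C(=O)O)nn(-c2ccccc2)c1-c1ccc(F)cc1`) gives > 680000 nM as its reading, and that reading is a limit of the assay. For the measured compounds named here, compound 2 (`CC(C)(C)NCc1c(C(=O)O)nn(-c2ccccc2)c1-c1ccc(Cl)cc1`) gives 364000 nM in this assay and holds the only number so far. Compound 3 (`CC(C)(C)NCc1c(C(=O)O)nn(-c2ccccc2)c1-c1ccc(Br)cc1`) is reached from compound 2 by one exchange (bromo in place of chloro on an aromatic carbon): bromo in place of chloro on an aromatic carbon. Going by the values given here, one measured step bears on it, the chloro in place of fluoro exchange on that same aromatic carbon (an at least 1.8-fold lower number from compound 1 to compound 2 (0.27 log units; that floor lies within the scatter)), and its floor lies within the scatter. On that step alone, no change beyond the scatter is expected in this assay from the bromo exchange. The estimated step is a 1.2-fold lower number from compound 2 to compound 3 (0.08 log units; within the scatter) and no larger. Compound 3 is expected at 300000 nM as a middle value, with an estimated range from 140000 nM to 620000 nM around it.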

Compound 3, concentration for 50% growth inhibition: > 585000 nM
Compound 3 was reported as a limit (the forecaster's own chance of this, stated with the estimate: 15%); at least 1.9-fold (0.29 log units) between middle value and limit.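

Bromo in place of chloro at this position, para to a large group, gives in this assay an at least 1.6-fold higher number from compound 2 to compound 3 (0.20 log units; that floor lies within the scatter); like the floor of the earlier chloro step, this one gives the halogens no order here. The reading of compound 3 is a limit of the assay and not a number: the limit of > 585000 nM in this assay, at which 1 of the 3 values shown sits. The step from compound 1 to compound 3 cannot be read, because the readings at both ends are limits: the limit of > 680000 nM in this assay, at which 1 of the 3 values shown sits.

From the compounds shown here alone, it remains open how an amine or a methoxy group on this aromatic carbon would read in this assay. The compounds also leave open how a methyl ester in place of the carboxylic acid would read on the shared core.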